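This account rests on a few compounds, and the source may have more. Where it says the series, first, only, none or still open, it means among the compounds named here.

Measured so far:
Compound 1, `COc1ccc(C(=O)N(C)c2ccc3[nH]c(-c4n[nH]c5ccccc45)cc3n2)cc1`: 23700 nM
Compound 2, `Cc1ccc(S(=O)(=O)N(C)c2ccc3[nH]c(-c4n[nH]c5ccccc45)cc3n2)cc1`: 16300 nM

In a functional assay on SMMC-7721 cells (Homo sapiens) for antiproliferative activity, read by MTT assay, with a stated time of 72 h (on this read-out lower numbers stand for stronger inhibition and higher numbers for weaker inhibition), compound 2 gives 16300 nM, and compound 1 gives 23700 nM. Among the measured compounds shown here, the only measured step, a 1.5-fold lower number from compound 1 to compound 2 (0.16 log units; within the scatter), lies within the scatter, so the two compounds cannot be told apart on these numbers, and compound 2 stands where compound 1 does.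

Compound 3, `CN(c1ccc2[nH]c(-c3n[nH]c4ccccc34)cc2n1)S(=O)(=O)c1ccc(Cl)cc1`, differs from compound 2 in one place: chloro in place of methyl on an aromatic carbon. For the measured compounds named here, no measured step bears directly on this change. Going by the values given here, the one step available replaces the whole group on the ring nitrogen, and even that larger change stayed within the scatter. Among the compounds with values here, with a single atom exchanged at the far end of the sulfonyl aryl ring, and no precedent for such an exchange, no step beyond the scatter is expected; the expected step is a 1.1-fold lower number from compound 2 to compound 3 (0.04 log units; within the scatter). Compound 3 is therefore estimated at 15000 nM in this assay, with a range from 6000 nM to 40000 nM.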

Compound 3, half-maximal inhibitory concentration: 12700 nM
For compound 3 the middle estimate is 1.2-fold (0.07 log units) above the measured one, and the stated range covers the measured number.
By their numbers in this assay, from the lowest: compounds 3, 2 and 1 (each within the scatter of the next).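

In this assay, among the compounds shown here, chloro in place of methyl on an aromatic carbon, para to a large group, gives a 1.3-fold lower number from compound 2 to compound 3 (0.11 log units; within the scatter) and so stays within the scatter, which gives the series its only direct reading at this position: on these numbers, the two groups cannot be told apart there. The larger replacement on the same nitrogen, (4-chlorophenyl)sulfonyl in place of (4-methoxyphenyl)carbonyl, gives a 1.9-fold lower number from compound 1 to compound 3 (0.27 log units; within the scatter) and also stays within the scatter, so neither this single-atom exchange nor the exchange of the whole group separates the compounds in this assay. Nothing available here bears on what lies behind these numbers.

Going by these compounds, with only methyl and chloro compared directly at this ring carbon, it remains open whether a group of another kind there, such as an amine or a carboxylic acid, would move the number beyond the scatter. On these data alone, it is equally open what a longer chain in place of the methyl on the nitrogen, or a change to the shared core, would do.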